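Half-life notes: phenethyl in place of 4-hydroxyphenyl

The source may report more compounds than this note shows. Statements on the series, on what has been measured and on what is new or still open speak of the compounds shown alone.

Measured in an ADME assay, in phosphate buffer, at 28 degrees C, at pH 7.0; on this read-out lower numbers stand for a shorter-lived compound and higher numbers for a longer-lived compound:
compound 1 `CC(C)(C)C1=C(C(=O)O)N2C(=O)[C@H](CO)[C@H]2O1` gives 5 h
compound 2 `CC(C)(C)C1=C(C(=O)O)N2C(=O)[C@H]([C@@H](O)c3ccccc3)[C@H]2O1` gives 8.9 h
compound 3 `CC(C)(C)C1=C(C(=O)O)N2C(=O)[C@H]([C@@H](O)c3ccc(O)cc3)[C@H]2O1` gives 10.3 h

Compound 3 holds the highest of the three numbers, though a 1.2-fold higher number from compound 2 to compound 3 (0.06 log units; within the scatter) is within the scatter, whereas a 2.1-fold higher number from compound 1 to compound 3 (0.31 log units; beyond the scatter) is beyond it. Compound 4 `CC(C)(C)C1=C(C(=O)O)N2C(=O)[C@H]([C@@H](O)CCc3ccccc3)[C@H]2O1` differs from compound 3 by phenethyl in place of 4-hydroxyphenyl on a saturated chain carbon bound to an oxygen on a saturated carbon and a saturated ring carbon. Within the data shown here, two measured steps bear on this: a 1.2-fold higher number from compound 2 to compound 3 (0.06 log units; within the scatter), which the loss of the aromatic hydroxy essentially reverses, and a 1.8-fold higher number from compound 1 to compound 2 (0.25 log units; within the scatter), which shows that an aromatic group at this position moves the number little. Among the measured compounds shown here, no measured pair probes the two-carbon chain between ring and the hydroxy-bearing carbon. Compound 4 is therefore expected to sit near compound 2, with a 1.2-fold lower number from compound 3 to compound 4 (0.08 log units; within the scatter) and no step beyond the scatter; the estimate for compound 4 is 8.5 h, ranging from 5 h to 14 h.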

Compound 4, half-life: 39 h
Beside the measured number, compound 4's estimate is 4.6-fold (0.66 log units) below it; measured number outside the range, above it.
By their numbers in this assay, from the lowest: compounds 1, 2 and 3 (each within the scatter of the next, the first and the last beyond it); then compound 4.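

In this assay phenethyl at this saturated chain carbon stands apart from every earlier group, with steps beyond the scatter from 4-hydroxyphenyl (a 3.8-fold higher number from compound 3 to compound 4 (0.58 log units; beyond the scatter)), from phenyl (a 4.4-fold higher number from compound 2 to compound 4 (0.64 log units; beyond the scatter)) and from hydrogen (a 7.8-fold higher number from compound 1 to compound 4 (0.89 log units; beyond the scatter)). Phenyl and 4-hydroxyphenyl lie within the scatter of each other, so the aromatic ring alone does not set compound 4 apart; the higher number goes with the phenethyl group, which carries the same ring on a chain.

Going by these compounds, whether benzyl, a longer chain or an amine on the chain would keep this half-life remains open. Nothing at hand gives a reason for the step.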